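This account rests on a few compounds, and the source may have more. Where it says the series, first, only, none or still open, it means among the compounds named here.

Values measured in a functional assay on cells (Panel CNS (Carcinoma cell lines), Homo sapiens) for inhibition, read by sulforhodamine B assay, with a stated time of 48 h (a lower number here means a stronger inhibitor of growth, a higher number a weaker inhibitor of growth), for the series are these
- compound 1 `CN1CCN(CCCOc2cccc3nc(Nc4ccc(Cl)c(C(F)(F)F)c4)ccc23)CC1` gives 3670 nM
- compound 2 `CN1CCN(CCCOc2cccc3nc(Nc4ccc(Cl)c(F)c4)ccc23)CC1` gives 3350 nM
- compound 3 `CN1CCN(CCCOc2cccc3nc(Nc4cc(Cl)cc(Cl)c4)ccc23)CC1` gives 3260 nM

Compound 1 at 3670 nM lies within the scatter of both other compounds, so the three values form a single level with no order among them.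

Compound 4 `CN1CCN(CCCOc2cccc3nc(Nc4cccc(Cl)c4)ccc23)CC1` is not yet measured. Relative to compound 1 it carries 3-chlorophenyl in place of 4-chloro-3-(trifluoromethyl)phenyl on a nitrogen on an aromatic ring. The core and the side chain stay the same.

For the measured compounds named here, three measured steps bear on this change, since each alters the group on that same nitrogen. They are a 1.1-fold lower number from compound 1 to compound 2 (0.04 log units; within the scatter), then a 1.1-fold lower number from compound 1 to compound 3 (0.05 log units; within the scatter), and a 1.0-fold lower number from compound 2 to compound 3 (0.01 log units; within the scatter). All three stay within the scatter, and none of the three compounds goes against this flat picture. The group in compound 4 itself has not been tested, so the expectation rests on these three compounds alone.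

No change beyond the scatter is expected in this assay, and the estimated step is a 1.1-fold lower number from compound 1 to compound 4 (0.03 log units; within the scatter). For compound 4 the expected value is 3400 nM, with an estimated range from 2000 nM to 5800 nM.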

Compound 4, concentration for total growth inhibition: 4000 nM
Estimate against measurement, compound 4: 1.2-fold (0.07 log units) below; low and high end bracket the measured number.
By their numbers in this assay, from the lowest: compounds 3, 2, 1 and 4 (each within the scatter of the next).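

In this assay the group on the nitrogen can shrink from 4-chloro-3-(trifluoromethyl)phenyl, with 11 heavy atoms, to 3-chlorophenyl, with 7 heavy atoms, and the result is a 1.1-fold higher number from compound 1 to compound 4 (0.04 log units; within the scatter) and no departure from the flat level. Hydrogen in place of one chloro of the 3,5-dichlorophenyl group gives a 1.2-fold higher number from compound 3 to compound 4 (0.09 log units; within the scatter) as the series' first step that removes a ring substituent without replacing it, and the change from 4-chloro-3-fluorophenyl gives a 1.2-fold higher number from compound 2 to compound 4 (0.08 log units; within the scatter) as well, so a single chloro on this ring reads at the same level as all three more heavily substituted groups. No available measurement offers an explanation for this flat response.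

Every compound shown keeps at least one chloro on this ring, so it remains open whether a phenyl with no chloro at all, or one carrying an amine or a carboxylic acid, would leave this level. Going by these compounds, the side chain is also constant across the series, and how a longer chain in that place would read is equally open.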